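The source may hold more compounds than are shown below. What is called first, only, known or untested is meant among the compounds shown, and "the series" means these compounds.

Measured so far in an assay on isolated protein for inhibition of hexokinase-1 (Rattus norvegicus), with a stated time of 6 h, tested at 10 mM; a higher number here means more inhibition at the concentration tested (going by the name of the read-out), a lower number less inhibition:
compound 1 `O=C(CI)NCCCCCCCCNc1ncnc2c1ncn2[C@@H]1O[C@H](COP(=O)(O)OP(=O)(O)OP(=O)(O)O)[C@@H](O)[C@H]1O` gives 35%
compound 2 `O=C(CI)NCCCCNc1ncnc2c1ncn2[C@@H]1O[C@H](COP(=O)(O)OP(=O)(O)OP(=O)(O)O)[C@@H](O)[C@H]1O` gives 0%
compound 3 `Nc1ncnc2c1nc(NCCCCCCNC(=O)CI)n2[C@@H]1O[C@H](COP(=O)(O)OP(=O)(O)OP(=O)(O)O)[C@@H](O)[C@H]1O` gives 0%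

Among the compounds with values here, the one counted step, a number 35 percentage points lower from compound 1 to compound 2 (beyond the scatter), comes with the change (((iodomethyl)carbonyl)amino in place of 4-(((iodomethyl)carbonyl)amino)butyl on a saturated chain carbon, four bonds along the chain from a nitrogen on an aromatic ring). Compound 3 stands level with compound 2 at the digits printed, the two together the lowest of the three numbers; the difference between the core of compound 3 and that of compound 1 is not broken down here.

Compound 4 `Nc1ncnc2c1nc(NCCNC(=O)CI)n2[C@@H]1O[C@H](COP(=O)(O)OP(=O)(O)OP(=O)(O)O)[C@@H](O)[C@H]1O` awaits measurement. It carries the same kind of change from compound 3, (((iodomethyl)carbonyl)amino in place of 4-(((iodomethyl)carbonyl)amino)butyl on a saturated chain carbon, two bonds along the chain from a nitrogen on an aromatic ring), the place now two bonds along the chain from a nitrogen on an aromatic ring rather than four. The expectation rests on compound 3 giving 0%, with the shorter chain of compound 2 giving 0%. The expected step is therefore a number 2 percentage points higher from compound 3 to compound 4 (within the scatter). Compound 4 is expected to give 2%, estimated to fall between 0% and 12%.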

Compound 4, a percentage reported as inhibition, at one concentration (the size of the read-out at that concentration, not a potency): 0%
The estimate for compound 4 lay 2 percentage points above the measured number; low and high end bracket the measured number.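

In this assay, the same shortening of the chain gives steps of different size on the two cores: the same change on two cores in this assay, a number 35 percentage points lower (beyond the scatter) from compound 1 to compound 2 and no change at the digits printed (within the scatter) from compound 3 to compound 4, 35 percentage points apart, beyond the scatter of two such steps

The new step is no change at the digits printed from compound 3 to compound 4 (within the scatter). It starts from the bottom of the read-out, so it cannot show whether the change would lower inhibition on this core, and the difference between the two steps does not show that chain length is without effect there.

Still open, going by these compounds, is whether a longer chain than 6-(((iodomethyl)carbonyl)amino)hexyl on the core of compound 3 would lift inhibition above zero. Also open, on these data alone, is how an amine or a carboxylic acid in place of the ((iodomethyl)carbonyl)amino group would read on either core.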